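A few compounds are considered here, and "the series" means these few. Any claim that something is new, unique, unknown or untested is made for them only; others in the source may bear on it.

In a functional assay on CCRF-CEM cells (Homo sapiens) for inhibition (on this read-out higher numbers stand for weaker inhibition and lower numbers for stronger inhibition), compound 1 `COc1ccc(/C=C2\CCCc3ccccc3C2=O)cc1` gives 350 nM, while compound 2 `O=C1CCCCC/C1=C\c1ccc(F)cc1` gives 198000 nM. That is the higher of the two numbers, well beyond the usual scatter, so compound 2 is the weaker inhibitor. Compound 3 `COc1ccc(/C=C2\CCCCCC2=O)cc1` keeps the core of compound 2 and changes one group: methoxy in place of fluoro on an aromatic carbon. Compound 1 also carries a methoxy, on a different core, and reads 350 nM, so a moderate move towards stronger inhibition, beyond the scatter, is expected. The expected change is a 5.0-fold lower number from compound 2 to compound 3 (0.69 log units; beyond the scatter). For compound 3 the estimate is 40000 nM, within a range of 6000 nM to 200000 nM.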

Compound 3, half-maximal inhibitory concentration: 194000 nM
For compound 3 the middle estimate is 4.9-fold (0.69 log units) below the measured one; low and high end bracket the measured number.
By their numbers in this assay, from the lowest: compound 1; then compounds 3 and 2 (each within the scatter of the next).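

On the shared core, methoxy in place of fluoro on the aromatic carbon gives a 1.0-fold lower number from compound 2 to compound 3 (0.01 log units; within the scatter) in this assay, so this swap leaves the number where it was. Although methoxy adds a hydrogen-bond acceptor and one more heavy atom than fluoro, neither difference shows up in this read-out. A methoxy at this position is therefore not enough on its own to give strong inhibition on this core.

From the compounds shown here alone, it remains open whether an amine, a carboxylic acid or a longer chain at this position would shift the number, and whether the same swap would also leave the number unchanged on the core of compound 1. No measurement at hand accounts for the lack of a change.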